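A few compounds are considered here, and "the series" means these few. Any claim that something is new, unique, unknown or untested is made for them only; others in the source may bear on it.

Measured in a functional assay on K562 cells (Homo sapiens), with a stated time of 48 h; a higher number here means that more compound is needed for the effect, a lower number that less compound is needed:
- Compound 1 `COc1ccc(/C=C\c2ccc3c(c2)C(C)(C)CCC3(C)C)cc1N`: 50000 nM
- Compound 2 `CC1(C)CCC(C)(C)c2cc(/C=C\c3ccc(N)cc3)ccc21`: > 100000 nM (a limit)

Compound 2 stands at > 100000 nM, which is a limit of this assay and not a number. Compound 3 `CC1(C)CCC(C)(C)c2cc(/C=C\c3cccc(N)c3)ccc21` keeps the shared core and differs from compound 2 as follows: 3-aminophenyl in place of 4-aminophenyl on a double-bonded chain carbon bound to a double-bonded chain carbon. For the measured compounds named here, the only numerical reading so far is compound 1 at 50000 nM, so the expectation stays near that value. A modest move towards a lower number is expected, an estimated at least 1.6-fold lower number from compound 2 to compound 3 (0.22 log units; that floor lies within the scatter), and compound 3 may also reach the limit. For compound 3 the expected value is 60000 nM, with an estimated range of 20000 nM to 100000 nM.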

Compound 3, concentration for half-maximal activity: 27000 nM
The estimate for compound 3 lay 2.2-fold (0.35 log units) above the measured number; low and high end bracket the measured number.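

In this assay, 3-aminophenyl in place of 4-aminophenyl on a double-bonded chain carbon bound to a double-bonded chain carbon gives an at least 3.7-fold lower number from compound 2 to compound 3 (0.56 log units; beyond the scatter), so where the amine sits on the phenyl counts in this series. Compound 2 stands at a limit, which makes that step a bound and not an exact size: the limit of > 100000 nM in this assay, at which 1 of the 3 values shown sits. Hydrogen in place of methoxy on an aromatic carbon gives a 1.9-fold lower number from compound 1 to compound 3 (0.27 log units; within the scatter), so this pair shows no difference that can be told from the scatter.

From the compounds shown here alone, whether a hydroxyl group or an acetamide could stand in place of the amine in compound 3 stays open. So does what a fluorine in place of the methoxy of compound 1 would give.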